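The compounds below may be only part of what the source reports. "The series", "measured", "known", "first", "only" and "open" are said of these compounds alone.

Measured so far in a functional assay on RPMI 8402 cells (Homo sapiens) for cytotoxicity; on this read-out lower numbers stand for stronger inhibition and higher numbers for weaker inhibition:
Compound 1 `CCCc1ccc2[nH]c(-c3ccc4[nH]c(-c5ccc6[nH]cnc6c5)nc4c3)nc2c1` — 20000 nM
Compound 2 `N#Cc1ccc2[nH]c(-c3ccc4[nH]c(-c5ccc6[nH]cnc6c5)nc4c3)nc2c1` — > 25000 nM, a limit of the assay rather than a number.

Compound 2 therefore sits at the limit of > 25000 nM in this assay, at which 1 of the 2 values shown sits; it has only a limit and no number. Compound 3 `c1cc(-c2ccc3[nH]c(-c4ccc5[nH]c(-c6ccc7[nH]cnc7c6)nc5c4)nc3c2)ccn1` differs from compound 2 by pyridin-4-yl in place of cyano on an aromatic carbon. Within the data shown here, the one measured step, an at least 1.2-fold higher number from compound 1 to compound 2 (0.09 log units; that floor lies within the scatter), concerns a different exchange at the same place and stays within the scatter, so it gives no pull in either direction. Both measured compounds are weak, and compound 3 is expected to stay weak as well. Compound 3 is estimated at 25000 nM, with a range from 8000 nM to 80000 nM. That estimate means a number no higher from compound 2 to compound 3 (the limit leaves the size open), and a further limit-only result remains likely.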

Compound 3, half-maximal inhibitory concentration: 2500 nM
Compound 3: the middle estimate sits 10-fold (1.00 log units) above what was measured, and the stated range ends above it.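

At this aromatic carbon, the exchange now moves the read-out beyond the scatter: in this assay pyridin-4-yl gives an 8.0-fold lower number from compound 1 to compound 3 (0.90 log units; beyond the scatter) against propyl and an at least 10-fold lower number from compound 2 to compound 3 (1.00 log units; beyond the scatter) against cyano. The second size is only a floor, since compound 2 has a limit of the assay and not a number: the limit of > 25000 nM in this assay, at which 1 of the 3 values shown sits.

As far as these compounds go, what phenyl, which has no ring nitrogen, or a small amine would give at this carbon remains open. The gain therefore cannot yet be tied to the added ring or to its nitrogen.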